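Two measured compounds and a rearranged third

The compounds below may be only part of what the source reports. "The series", "measured", "known", "first", "only" and "open" are said of these compounds alone.

Measured so far:
compound 1 `O=C1CCCN1C1=CC(CF)(CF)Oc2ccc([N+](=O)[O-])cc21` gives 7.76 nM in a functional assay (aorta) with Rattus norvegicus as the target; on this read-out lower numbers stand for an effect already at smaller amounts and higher numbers for an effect only at larger amounts of compound;
compound 2 `O=c1ccccn1C1=CC(CF)(CF)Oc2ccc([N+](=O)[O-])cc21` gives 2.46 nM.

Within the data shown here, compound 2 stands lowest of the two numbers; its only neighbour is compound 1, with a 3.2-fold lower number from compound 1 to compound 2 (0.50 log units; beyond the scatter). Compound 3 `O=[N+]([O-])c1ccc2c(c1)C(c1cccc[n+]1[O-])=CC(CF)(CF)O2` is built from the same atoms as compound 2, joined differently: a group of 7 heavy atoms (5 carbon, 1 nitrogen, 1 oxygen; one six-membered aromatic ring with 1 hetero atom) in place of a group of 7 heavy atoms (5 carbon, 1 nitrogen, 1 oxygen; one six-membered aromatic ring with 1 hetero atom), on a double-bonded ring carbon. Among the measured compounds shown here, no measured step shows this kind of rearrangement; the single known step, from compound 1 to compound 2, concerns a different exchange and offers no guide. An expected change of a 1.6-fold higher number from compound 2 to compound 3 (0.21 log units; within the scatter) is therefore a guess near no change, with wide bounds. Compound 3 is expected to give 4 nM, estimated between 1.3 nM and 13 nM.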

Compound 3, half-maximal effective concentration: 1.74 nM
Compound 3: middle estimate off by 2.3-fold (0.36 log units), on the high side; the range from low to high includes it.
By their numbers in this assay, from the lowest: compounds 3 and 2 (each within the scatter of the next); then compound 1.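

In this assay the rearrangement gives a 1.4-fold lower number from compound 2 to compound 3 (0.15 log units; within the scatter), so at this position the six-membered aromatic ring can be joined in either way with no change that stands out from the scatter. The ring as joined in compound 3 also keeps the advantage over the five-membered non-aromatic ring, with a 4.5-fold lower number from compound 1 to compound 3 (0.65 log units; beyond the scatter). No measurement available here explains these results. From the compounds shown here alone, it remains open whether a plain phenyl ring or an amine on the same double-bonded ring carbon would give a number in this range.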